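The source may hold more compounds than are shown below. What is called first, only, known or untested is meant among the compounds shown, and "the series" means these compounds.

Values in a physicochemical assay for solubility, read by HPLC, with a stated time of 24 h (a lower number here means a less soluble compound, a higher number a more soluble compound), for the measured compounds:
- Compound 1 (`CC(C)(C)c1[nH]cnc1/C=c1\[nH]c(=O)/c(=C/c2cccc(C(=O)c3ccccc3)c2)[nH]c1=O`) gives < 0.1 ug/mL (a limit)
- Compound 2 (`CC(C)(C)c1[nH]cnc1/C=c1\[nH]c(=O)/c(=C/c2cccc(C(=O)N3CCCC3)c2)[nH]c1=O`) gives 0.454 ug/mL (a number)
- Compound 3 (`CC(C)(C)c1[nH]cnc1/C=c1\[nH]c(=O)/c(=C/c2cccc(C(=O)N3CCCCC3)c2)[nH]c1=O`) gives < 0.1 ug/mL (a limit)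

Compound 3 therefore has no exact value in this assay. It stands at the limit of < 0.1 ug/mL in this assay, at which 2 of the 3 values shown sit, and can be read only as a limit. The next compound, compound 4 (`CC(C)(C)c1[nH]cnc1/C=c1\[nH]c(=O)/c(=C/c2cccc(C(=O)c3ccncc3)c2)[nH]c1=O`), differs from compound 3 by one change: pyridin-4-yl in place of piperidin-1-yl on a carbonyl carbon. In words, pyridin-4-yl stands in place of piperidin-1-yl on a carbonyl carbon.

Within the data shown here, no measured step makes this exact exchange, but three steps change the same group. Replacing phenyl with pyrrolidin-1-yl gave an at least 4.5-fold higher number from compound 1 to compound 2 (0.65 log units; beyond the scatter) and replacing pyrrolidin-1-yl with piperidin-1-yl gave an at least 4.5-fold lower number from compound 2 to compound 3 (0.65 log units; beyond the scatter) in turn. The remaining pair shows a step that the two limits leave unreadable from compound 1 to compound 3 and offers no size to use.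

The closest measured compound is compound 1, which also has a six-membered aromatic ring on the carbonyl carbon, and its < 0.1 ug/mL is likewise a limit. Given that limit for compound 1, only a small rise is expected, and the result may again be reported as a limit. The expected change is an at least 2.0-fold higher number from compound 3 to compound 4 (0.30 log units; that floor lies within the scatter) in this estimate. Compound 4 is estimated at 0.2 ug/mL with an expected range from 0.06 ug/mL to 0.7 ug/mL in this assay.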

Compound 4, solubility: < 0.1 ug/mL
Compound 4 was reported as a limit; the forecaster's own chance of this, stated with the estimate: 40%; middle value at least 2.0-fold (0.30 log units) from the limit.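

In this assay compound 4 gives < 0.1 ug/mL, a limit, so pyridin-4-yl on the carbonyl carbon, a six-membered aromatic ring with one hetero atom and one hydrogen-bond acceptor, does not yield a readable number at this position. Pyridin-4-yl in place of pyrrolidin-1-yl gives an at least 4.5-fold lower number from compound 2 to compound 4 (0.65 log units; beyond the scatter), which leaves compound 2 as the only compound shown with a number and extends the drop already seen with piperidin-1-yl to a third group. The steps to compound 4 from compound 1 and from compound 3 cannot be read, and the compounds shown now gather at a single limit: the limit of < 0.1 ug/mL in this assay, at which 3 of the 4 values shown sit.

From the compounds shown here alone, how far compound 1, compound 3 and compound 4 lie under that limit stays unknown, so no order among phenyl, piperidin-1-yl and pyridin-4-yl can be drawn. Going by these compounds, it also remains open whether the number seen with pyrrolidin-1-yl is particular to that ring, or whether another group on the carbonyl carbon, such as morpholin-4-yl, dimethylamino or azetidin-1-yl, would also give a reading above the limit.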